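This account rests on a few compounds, and the source may have more. Where it says the series, first, only, none or still open, it means among the compounds named here.

Measured so far in a physicochemical assay for solubility, read by spectrophotometry, in phosphate buffer, with a stated time of 2 h, at pH 7.4; a higher number here means a more soluble compound, a lower number a less soluble compound:

compound 1 `COc1ccc2[nH]c(C(=O)N3CC(=O)N(Cc4ccccc4)[C@@H](CN4CCCCC4)C3)cc2c1` — > 25000 nM

compound 2 `Cc1ccc2[nH]c(C(=O)N3CC(=O)N(Cc4ccccc4)[C@@H](CN4CCC5(CCC5)CC4)C3)cc2c1` — 12300 nM

compound 3 `O=C(c1cc2cc(C3CC3)ccc2[nH]1)N1CC(=O)N(Cc2ccccc2)[C@@H](CN2CCN(Cc3ccccc3)CC2)C1` — 12900 nM

Compound 1 sits at the limit of this assay, (the limit of > 25000 nM in this assay, at which 1 of the 3 values shown sits), so its solubility is known only as a limit and not as a number. Compound 2 gives 12300 nM and compound 3 gives 12900 nM, values within the usual scatter of each other.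

Compound 4 `COc1ccc2[nH]c(C(=O)N3CC(=O)N(Cc4ccccc4)[C@@H](COc4ccc(F)cc4)C3)cc2c1` has not yet been measured. It differs from compound 1 in one place: 4-fluorophenoxy in place of piperidin-1-yl on a saturated chain carbon bound to a saturated ring carbon. Going by the values given here, no measured pair shows this change, so nothing among the known values tells its size. The expectation is that compound 4 falls below compound 1, with a step of an at least 8.3-fold lower number from compound 1 to compound 4 (0.92 log units; beyond the scatter) in this assay. Compound 4 is estimated at 3000 nM, expected to lie between 500 nM and 15000 nM.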

Compound 4, solubility: 17500 nM
Estimate against measurement, compound 4: 5.8-fold (0.77 log units) below; the measured number lies above the stated range.
By their numbers in this assay, from the lowest: compounds 2, 3 and 4 (each within the scatter of the next). At a limit, above all of these: compound 1.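

Going by these compounds alone, the step of an at least 1.4-fold lower number from compound 1 to compound 4 (0.15 log units; that floor lies within the scatter) comes with 4-fluorophenoxy in place of piperidin-1-yl on a saturated chain carbon bound to a saturated ring carbon, and it is the first step that can be read at this place. In this assay compound 4, whose group here holds no nitrogen, gives 17500 nM as a plain number, so a nitrogen in this group is not needed for a value of this size. The true size of the step stays unknown, since compound 1 is a limit and not a number: the limit of > 25000 nM in this assay, at which 1 of the 4 values shown sits.

Still open, on these data alone, is how phenoxy without the fluorine, a morpholine ring or a carboxylic acid would compare at this place.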